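The source may report more compounds than this note shows. Statements on the series, on what has been measured and on what is new or still open speak of the compounds shown alone.

In a functional assay (Pituitary gland cell) with Rattus norvegicus as the target (on this read-out lower numbers stand for an effect already at smaller amounts and higher numbers for an effect only at larger amounts of compound), compound 1 `CC(C)(N)CC(=O)N[C@@H]1CCc2ccccc2N(Cc2ccc(-c3ccccc3C(N)=O)cc2)C1=O` gives 0.08 uM and compound 2 `CCN(CC)C(=O)c1ccccc1-c1ccc(CN2C(=O)[C@H](NC(=O)CC(C)(C)N)CCc3ccccc32)cc1` gives 2 uM as the higher of the two numbers. Compound 3 `CC(C)(N)CC(=O)N[C@@H]1CCc2ccccc2N(Cc2ccc(-c3ccccc3C(=O)NCCCCCO)cc2)C1=O` carries (5-hydroxypentyl)amino in place of diethylamino on a carbonyl carbon. Among the compounds with values here, the only measured step at this place is large and beyond the scatter: a 25-fold higher number from compound 1 to compound 2 (1.40 log units; beyond the scatter) on replacing amino with diethylamino. Compound 3 regains the amide hydrogen that compound 1 has at 0.08 uM and that diethylamino lacks. A moderate move toward a lower number is therefore expected, a 10-fold lower number from compound 2 to compound 3 (1.00 log units; beyond the scatter) in size and recovering only part of that gap. The estimate for compound 3 is 0.2 uM with an expected range from 0.05 uM to 0.8 uM on this read-out.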

Compound 3, concentration for half-maximal effect: 0.01 uM
Beside the measured number, compound 3's estimate is 20-fold (1.30 log units) above it, outside the stated range (below it).
By their numbers in this assay, from the lowest: compound 3; then compound 1; then compound 2.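

In this assay, (5-hydroxypentyl)amino in place of diethylamino gives a 200-fold lower number from compound 2 to compound 3 (2.30 log units; beyond the scatter) and so more than closes the gap opened by diethylamino. 5-hydroxypentyl in place of hydrogen on the amide-type nitrogen gives an 8.0-fold lower number from compound 1 to compound 3 (0.90 log units; beyond the scatter) and shows that substitution on this nitrogen does not by itself raise the number, with compound 2 going the other way. No available evidence accounts for the difference between these substituents.

Open, going by these compounds, is whether the lower number follows the hydroxyl or the pentyl chain. A plain pentyl group, a longer chain or an amine in place of the hydroxyl would separate these.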